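Acyloxymethyl ester variation and metabolic stability

This account rests on a few compounds, and the source may have more. Where it says the series, first, only, none or still open, it means among the compounds named here.

Measured so far:
compound 1 `CCC(CC)C(=O)OCOC(=O)C1=C(S[C@@H]2CN[C@H](C(=O)Nc3cccc(C(=O)O)c3)C2)[C@H](C)[C@@H]2[C@@H]([C@@H](C)O)C(=O)N12`: > 95%
compound 2 `C[C@@H](O)[C@H]1C(=O)N2C(C(=O)OCOC(=O)OC(C)(C)C)=C(S[C@@H]3CN[C@H](C(=O)Nc4cccc(C(=O)O)c4)C3)[C@H](C)[C@H]12`: > 95%

In an ADME assay for metabolic stability, read by LC-MS, with a stated time of 3 h, at pH 6.5, tested at 50 uM (a higher number here means that more of the compound is left, a lower number that less of the compound is left), compound 1 gives > 95%, a limit of the assay. In this assay compound 2 gives > 95%, also a limit. The step that the two limits leave unreadable from compound 1 to compound 2 is unreadable because of the limit of > 95% in this assay, at which 2 of the 2 values shown sit. Compound 3 `CC(C)C(=O)OCOC(=O)C1=C(S[C@@H]2CN[C@H](C(=O)Nc3cccc(C(=O)O)c3)C2)[C@H](C)[C@@H]2[C@@H]([C@@H](C)O)C(=O)N12` differs from compound 2 by isopropyl in place of tert-butoxy on a carbonyl carbon. Among the measured compounds shown here, the only measured step touches the same carbonyl carbon, but its size is not readable, so no direction beyond the scatter can be taken from it. The expected step of a number at least 3 percentage points lower from compound 2 to compound 3 (that floor lies within the scatter) is therefore estimated as small. Compound 3 is estimated at 92%, between 78% and 99%.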

Compound 3, percent of the compound remaining: > 95%
Compound 3 was reported as a limit; the forecaster's own chance of this, stated with the estimate: 55%; middle value at least 3 percentage points from the limit.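

Among the compounds shown here, no step among compound 1, compound 2 and compound 3 can be read in this assay, because all three values sit at one limit: the limit of > 95% in this assay, at which 3 of the 3 values shown sit. The compounds shown leave open how far these three differ, and which change on this carbonyl carbon, if any, would give a value off the limit.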